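This account rests on a few compounds, and the source may have more. Where it says the series, first, only, none or still open, it means among the compounds named here.

Measured compounds: compound 1 `COc1ccccc1-c1nc(C)c(COc2cccc(C(=O)O)c2)o1`, compound 2 `COc1cccc(-c2nc(C)c(COc3cccc(C(=O)O)c3)o2)c1`, compound 3 `COc1ccccc1-c1nc(C)c(COc2ccc(CC(=O)O)cc2)o1`.

In an assay on cells for antagonist activity at vitamin D3 receptor (Homo sapiens), read by a luciferase reporter (on this read-out higher numbers stand for weaker inhibition and lower numbers for stronger inhibition), compound 1 reaches only a limit of the assay, > 100000 nM. Compound 2 gives 33100 nM in this assay. Compound 3 likewise reaches only a limit, > 80000 nM. The difference between the core of compound 1 and that of compound 3 is not broken down here. On these data alone, the change from compound 1 to compound 2 is 3-methoxyphenyl in place of 2-methoxyphenyl on an aromatic carbon, and it brings an at least 3.0-fold lower number from compound 1 to compound 2 (0.48 log units; beyond the scatter); the step stays open at the upper end because the limit of > 100000 nM in this assay, at which 1 of the 3 values shown sits, fixes the value of compound 1. Compound 4 `COc1cccc(-c2nc(C)c(COc3ccc(CC(=O)O)cc3)o2)c1`, not yet measured, carries the same change from compound 3, (3-methoxyphenyl in place of 2-methoxyphenyl on an aromatic carbon). The step of an at least 2.0-fold lower number from compound 3 to compound 4 (0.30 log units; that floor lies within the scatter) is expected, resting on an at least 3.0-fold lower number from compound 1 to compound 2 (0.48 log units; beyond the scatter) and on the limit of compound 3 given by the limit of > 80000 nM in this assay, at which 1 of the 3 values shown sits. Compound 4 is therefore estimated at 40000 nM in this assay, expected between 12000 nM and 120000 nM.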

Compound 4, half-maximal inhibitory concentration: 27700 nM
Compound 4: the middle estimate sits 1.4-fold (0.16 log units) above what was measured; the range from low to high includes it.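

In this assay, 3-methoxyphenyl in place of 2-methoxyphenyl also lowers the number on the second core, with an at least 2.8-fold lower number from compound 3 to compound 4 (0.46 log units; beyond the scatter). The change points the same way on both cores, and the two steps cannot be told apart in size: the same change on two cores in this assay, an at least 3.0-fold lower number (0.48 log units; beyond the scatter) from compound 1 to compound 2 and an at least 2.8-fold lower number (0.46 log units; beyond the scatter) from compound 3 to compound 4; the limit leaves it open whether they differ. Each step starts from a limit of the assay, which leaves its full size unknown, and two cores do not show that the change would carry to any other core.

The compounds shown leave open how a plain phenyl, or an amine or a hydroxyl in place of the methoxy group, would read in this assay. They also leave open what an amide in place of the carboxylic acid, or a longer chain leading to that acid, would do.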